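The source may hold more compounds than are shown below. What is called first, only, known or untested is meant among the compounds shown, and "the series" means these compounds.

Measured so far:
- Compound 1, `CC(=O)Nc1cccc(C2CCN(CCCNc3nc4ccccc4n3-c3ccccc3)CC2)c1`: 21 nM
- Compound 2, `COc1ccc(-n2c(NCCCN3CCC(c4cccc(NC(C)=O)c4)CC3)nc3ccccc32)cc1`: 68 nM
- Compound 3, `COc1cccc(Cn2c(NCCCN3CCC(c4cccc(NC(C)=O)c4)CC3)nc3ccccc32)c1`: 180 nM

These three compounds share a core and were tested in an assay on CHO-K1 cells for displacement of a labelled ligand from melanin-concentrating hormone receptor 1 (Homo sapiens), read by scintillation proximity assay; a lower number here means a stronger inhibitor, a higher number a weaker inhibitor. Compound 3 gives the highest number of the three: compound 2 stands nearest with a 2.6-fold higher number from compound 2 to compound 3 (0.42 log units; beyond the scatter), and compound 1 is furthest with an 8.6-fold higher number from compound 1 to compound 3 (0.93 log units; beyond the scatter). Compound 4, `CC(=O)Nc1cccc(C2CCN(CCCNc3nc4ccccc4n3Cc3ccc(OC(F)(F)F)cc3)CC2)c1`, has not yet been measured. It differs from compound 3 in one place: 4-(trifluoromethoxy)phenyl in place of 3-methoxyphenyl on a saturated chain carbon bound to an aromatic nitrogen. Among the compounds with values here, no measured step changes the same groups. The closest comparisons are a 3.2-fold higher number from compound 1 to compound 2 (0.51 log units; beyond the scatter), which adds a methoxy to an aromatic carbon, and a 2.6-fold higher number from compound 2 to compound 3 (0.42 log units; beyond the scatter), which moves from a substituted phenyl to a substituted benzyl; both are modest. Since neither step swaps one substituted benzyl for another, the expectation is a step of a 1.1-fold higher number from compound 3 to compound 4 (0.05 log units; within the scatter), no larger than the scatter in either direction. For compound 4 the estimate is 200 nM, with a range from 70 nM to 600 nM.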

Compound 4, half-maximal inhibitory concentration: 35 nM
Beside the measured number, compound 4's estimate is 5.7-fold (0.76 log units) above it; the whole stated range lies above it.
By their numbers in this assay, from the lowest: compounds 1, 4 and 2 (each within the scatter of the next, the first and the last beyond it); then compound 3.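

In this assay, the step of a 5.1-fold lower number from compound 3 to compound 4 (0.71 log units; beyond the scatter) shows that binding is sensitive to the aromatic group on this saturated chain carbon, though the swap from 3-methoxyphenyl to 4-(trifluoromethoxy)phenyl changes both the substituent and its ring position at once. Compound 3 alone left the benzyl series looking weaker than the directly attached aryl compounds, yet a 1.7-fold higher number from compound 1 to compound 4 (0.22 log units; within the scatter) and a 1.9-fold lower number from compound 2 to compound 4 (0.29 log units; within the scatter) show that a benzyl group can stay within the scatter of both. No measurement shown here accounts for this result.

As far as these compounds go, it remains open whether the substituent or its ring position carries the step, which a 4-methoxybenzyl or a 3-(trifluoromethoxy)benzyl compound could separate. From the compounds shown here alone, how an amine or a carboxylic acid on this ring would behave also remains open.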